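Swapping the terminal aryl ring of a terphenyl benzimidazole

The compounds below may be only part of what the source reports. "The series", "measured", "known", "first", "only" and "open" are said of these compounds alone.

Measured compounds:
compound 1, `Cc1ccc2[nH]c(-c3ccc(-c4ccc(-c5cccc(Cl)c5)cc4)cc3)nc2c1`, 1210 nM
compound 2, `Fc1ccc(-c2ccc(-c3ccc(-c4nc5ccccc5[nH]4)cc3)cc2)cc1`, 36200 nM

Of the compounds shown here, two have been measured in a functional assay on MCF7 cells (Homo sapiens) for inhibition, read by sulforhodamine B assay; a higher number here means a weaker inhibitor of growth, a lower number a stronger inhibitor of growth. Compound 1 gives 1210 nM. Compound 2 gives 36200 nM, the highest of the two numbers; its nearest neighbour is compound 1, and the gap between them lies beyond the scatter, so compound 2 is the weaker inhibitor of growth of the pair. Compound 1 and compound 2 differ in more than one place, so no single step can be read from them.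

Compound 3, `COc1ccc(-c2ccc(-c3ccc(-c4nc5ccccc5[nH]4)cc3)cc2)cc1OC`, has not yet been tested in this assay. It differs from compound 2 in one place: 3,4-dimethoxyphenyl in place of 4-fluorophenyl on an aromatic carbon. The ring that enters carries two hydrogen-bond acceptors where the ring that leaves carried none, and it sits on an aromatic carbon of a six-membered aromatic ring of carbon only, para to a large group.

Among the compounds with values here, no step isolates this change, so any expectation rests on compound 2 alone. Compound 3 is estimated to land at 15000 nM, within 4000 nM to 50000 nM, which means an expected step of a 2.4-fold lower number from compound 2 to compound 3 (0.38 log units; beyond the scatter) toward stronger growth inhibition, but of a size that could also fall within the scatter.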

Compound 3, concentration for 50% growth inhibition: 7600 nM
For compound 3 the middle estimate is 2.0-fold (0.30 log units) above the measured one, and the stated range covers the measured number.
By their numbers in this assay, from the lowest: compound 1; then compound 3; then compound 2.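

In this assay, the exchange of 4-fluorophenyl for 3,4-dimethoxyphenyl gives a 4.8-fold lower number from compound 2 to compound 3 (0.68 log units; beyond the scatter) and moves toward stronger growth inhibition, a modest step that lies beyond the scatter. Within the data shown here, this is the first change that can be read on its own, and it shows that the number responds to what the terminal ring carries at this place, on an aromatic carbon para to a large group: the entering ring has hydrogen-bond acceptors and the leaving ring has none, yet both are six-membered aromatic rings of carbon only. No measurement shown here explains the step.

The step replaces the fluorine and adds both methoxy groups at once, so it cannot say whether the gain comes from losing the fluorine, from either methoxy group alone or from the pair. As far as these compounds go, whether a single methoxy, a hydroxyl, or an amine or carboxylic acid on this ring would move the number further remains open, as does the part played by the chlorine and the methyl group of compound 1, which differs from compound 2 and compound 3 in more than one place.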